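This account rests on a few compounds, and the source may have more. Where it says the series, first, only, none or still open, it means among the compounds named here.

Of the compounds shown here, three from one series have been measured in a physicochemical assay for metabolic stability, read by LC-MS, in phosphate buffer, with a stated time of 3 h, at pH 7.4, tested at 50 uM; a lower number here means that less of the compound is left, a higher number that more of the compound is left. Compound 1, with the structure `Cc1oc(=O)oc1COC(=O)c1cccc(NC(=O)[C@@H]2C[C@H](SC3=C(C(=O)O)N4C(=O)[C@H]([C@@H](C)O)[C@H]4[C@H]3C)CN2)c1`, gives a reading of > 95%, which is a limit of the measurement rather than a number. Compound 2, with the structure `C[C@@H](O)[C@H]1C(=O)N2C(C(=O)OCOC(=O)C(C)(C)C)=C(S[C@@H]3CN[C@H](C(=O)Nc4cccc(C(=O)O)c4)C3)[C@H](C)[C@H]12`, gives > 95%, again a limit. Compound 3, with the structure `CC(OC(=O)C1=C(S[C@@H]2CN[C@H](C(=O)Nc3cccc(C(=O)OC(C)OC(=O)C(C)(C)C)c3)C2)[C@H](C)[C@@H]2[C@@H]([C@@H](C)O)C(=O)N12)OC(=O)C(C)(C)C`, gives > 95%, also a limit. Compound 2 therefore stands where the whole set stands, and nothing in the numbers separates it from compound 1 or compound 3, since all three sit at the same limit: the limit of > 95% in this assay, at which 3 of the 3 values shown sit.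

Compound 4, with the structure `CCOC(=O)C1=C(S[C@@H]2CN[C@H](C(=O)Nc3cccc(C(=O)O)c3)C2)[C@H](C)[C@@H]2[C@@H]([C@@H](C)O)C(=O)N12`, has not yet been measured in this assay. It differs from compound 2 in one place: methyl in place of ((tert-butyl)carbonyl)oxy on a saturated chain carbon bound to an oxygen next to a carbonyl group. Among the measured compounds shown here, no step between measured compounds of this kind is available, so the expectation rests on the three readings alone. The step from compound 2 to compound 4 is expected to be none beyond the usual scatter, with an estimated step that the limit leaves unreadable from compound 2 to compound 4. Compound 4 is expected to give about 96%, within a range from 85% to 100%, most likely reported again as a limit.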

Compound 4, percent of the compound remaining: > 95%
Compound 4 was reported as a limit (the forecaster's own chance of this, stated with the estimate: 80%); the middle value lies beyond the limit too.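

In this assay, no step can be read from compound 2 to compound 4, because both readings are limits rather than numbers: the limit of > 95% in this assay, at which 4 of the 4 values shown sit.

The compounds shown leave open whether the four differ at all in how much compound remains, and so whether putting methyl in place of ((tert-butyl)carbonyl)oxy makes any difference.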